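Trimming the Acid Chain: Expectations for Compound 3

This account rests on a few compounds, and the source may have more. Where it says the series, first, only, none or still open, it means among the compounds named here.

Measured compounds:
compound 1, `CCc1onc(NS(=O)(=O)c2ccc(C(C)(C)C)cc2)c1Sc1cccc(OC)c1`, gives 800 nM
compound 2, `COc1cccc(Sc2c(NS(=O)(=O)c3ccc(C(C)(C)C)cc3)noc2CCCC(=O)O)c1`, gives 4300 nM

Going by the values given here, in an assay on A7R5 cells for displacement of a labelled ligand from Endothelin-1 receptor (Rattus norvegicus) (a lower number here means a stronger inhibitor, a higher number a weaker inhibitor), compound 2 stands highest of the two numbers measured; its nearest neighbour is compound 1, and the only measured step is a 5.4-fold higher number from compound 1 to compound 2 (0.73 log units; beyond the scatter). That step attached a carboxymethyl group to the chain carbon and weakened binding beyond the scatter.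

Compound 3, `COc1cccc(Sc2c(NS(=O)(=O)c3ccc(C(C)(C)C)cc3)noc2CCC=O)c1`, is not yet measured. It differs from compound 2 by formyl in place of carboxymethyl on a saturated chain carbon, two bonds along the chain from an aromatic carbon. The chain is thus shortened and the acid is replaced by an aldehyde, which brings compound 3 partway back toward compound 1, the compound that carries no carboxymethyl group at all.

The step from compound 1 to compound 2 is the only one that bears on this change, and it points the other way: removing the carboxymethyl is expected to lower the number again, though the formyl group that enters is not a plain hydrogen, so only a partial return is estimated, a 2.9-fold lower number from compound 2 to compound 3 (0.46 log units; beyond the scatter). Compound 3 is therefore expected to give about 1500 nM, within a range of 500 nM to 4500 nM.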

Compound 3, half-maximal inhibitory concentration: 380 nM
Compound 3: middle estimate off by 3.9-fold (0.60 log units), on the high side; the measured number lies below the stated range.
By their numbers in this assay, from the lowest: compound 3; then compound 1; then compound 2.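

In this assay the exchange of carboxymethyl for formyl on this saturated chain carbon gives an 11-fold lower number from compound 2 to compound 3 (1.05 log units; beyond the scatter) and is a large change, so the end of this chain has a strong bearing on the number. Formyl in place of hydrogen at the same carbon gives a 2.1-fold lower number from compound 1 to compound 3 (0.32 log units; beyond the scatter) and so does more than recover what carboxymethyl lost: the two groups move the number in opposite directions relative to hydrogen, with compound 3 lowest of the three and compound 2 highest. Nothing given here explains why the two groups differ in this way.

The exchange alters both the group at the end of the chain and the heavy-atom count, and these three compounds cannot show how much of the change belongs to the shorter chain and how much to the loss of the acid. A carboxylic acid on a shorter chain, or a primary alcohol or an amide in place of the formyl group, would help to separate these two parts of the change.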